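This account rests on a few compounds, and the source may have more. Where it says the series, first, only, none or still open, it means among the compounds named here.

Measured so far:
compound 1, `COc1cc(/C=C/C(=O)Nc2ccccc2)ccc1OCCCN(C)C` — 1.55
compound 2, `COc1cc(/C=C/C(=O)Nc2ccccc2)ccc1OCCCN1CCCCC1` — 1.58
compound 3, `COc1cc(/C=C/C(=O)Nc2ccccc2)ccc1OCCCCCCN1CCCC1` — 1.76

In a physicochemical assay for lipophilicity, using the shake flask method, measured as octanol-water partition, at pH 7.4 (on this read-out higher numbers stand for higher lipophilicity and lower numbers for lower lipophilicity), compound 1 gives 1.55, the lowest of the three numbers, though neither of the other two lies beyond the scatter from it: the steps are a number 0.03 log units higher from compound 1 to compound 2 (within the scatter) and a number 0.21 log units higher from compound 1 to compound 3 (within the scatter). Compound 4, `COc1cc(/C=C/C(=O)Nc2ccccc2)ccc1OCCCCCCCCCCN(C)C`, has not been measured in this assay. It differs from compound 1 in one place: 7-(dimethylamino)heptyl in place of dimethylamino on a saturated chain carbon, three bonds along the chain from an oxygen on an aromatic ring.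

The step that bears on it most is that from compound 1 to compound 3, where a longer chain also entered and the result was a number 0.21 log units higher from compound 1 to compound 3 (within the scatter); the step of a number 0.18 log units higher from compound 2 to compound 3 (within the scatter) points the same way. Both were small, but the change to compound 4 adds a far longer chain than either. The expectation is therefore a step upward well beyond the scatter, estimated as a number 1.05 log units higher from compound 1 to compound 4 (beyond the scatter). Compound 4 is expected to give about 2.6, within a range from 1.9 to 3.4.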

Compound 4, partition coefficient: 1.8
For compound 4 the middle estimate is 0.80 log units above the measured one, outside the stated range (below it).
By their numbers in this assay, from the lowest: compounds 1, 2, 3 and 4 (each within the scatter of the next).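

In this assay, even 7-(dimethylamino)heptyl, with 10 heavy atoms entering where 3 leave, produces a number 0.25 log units higher from compound 1 to compound 4 (within the scatter) and so does not separate the two compounds at this position. Compound 4 also stays close to the compounds with ring amines, with a number 0.22 log units higher from compound 2 to compound 4 (within the scatter) and with a number 0.04 log units higher from compound 3 to compound 4 (within the scatter) as the other comparison, so none of the four compounds stands apart from the others, whatever the chain length or the amine. Nothing measured here explains why the long chain leaves the read-out so little changed.

Still open, from the compounds shown here alone, is whether a longer chain than that of compound 4 would give a step beyond the scatter. Also open, going by these compounds, is what a carboxylic acid in place of dimethylamino would do on the same chain.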